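Adding a carbamoyl side chain to compound 1

The source may hold more compounds than are shown below. What is called first, only, known or untested is meant among the compounds shown, and "the series" means these compounds.

Measured so far:
- compound 1 `CC[C@@H]1C(=O)N(C)c2cnc(-n3ccc4ccccc43)nc2N1C1CCCC1` gives 28300 nM
- compound 2 `CCCNS(=O)(=O)c1ccc(Nc2ncc3c(n2)N(C2CCCC2)[C@H](CC)C(=O)N3C)cc1` gives 2100 nM

In a functional assay on NCI-H1975 cells (Homo sapiens) for antiproliferative activity, read by CCK-8 assay, with a stated time of 72 h (a lower number here means a stronger inhibitor of growth, a higher number a weaker inhibitor of growth), compound 1 (28300 nM) holds the higher of the two numbers, beyond the scatter from compound 2. Compound 3 `CC[C@@H]1C(=O)N(C)c2cnc(-n3ccc4cc(C(=O)NCC(C)C)ccc43)nc2N1C1CCCC1` has isobutylcarbamoyl in place of hydrogen on an aromatic carbon of the core of compound 1 (isobutylcarbamoyl in place of hydrogen on an aromatic carbon). Among the compounds with values here, no measured step covers this change, so the expectation is loose. Within the data shown here, compound 2 (2100 nM) offers the only lower number to lean on. The step expected in this assay is a fall beyond the scatter (estimated a 5.7-fold lower number from compound 1 to compound 3 (0.75 log units; beyond the scatter)). Compound 3 is estimated at 5000 nM (range 1500 nM to 18000 nM).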

Compound 3, concentration for 50% growth inhibition: "not active" (no number reported)
Nothing numeric was reported for compound 3; the estimate stays without a comparison.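

In this assay, within the data shown here, compound 3 is reported as not active, without a number, so no step from compound 1 can be read. No measured evidence bears on this result. The compounds shown leave open whether any carbamoyl side chain at this place gives a measurable growth inhibition.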